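Removing the methyl from compound 3: working notes

The source may hold more compounds than are shown below. What is called first, only, known or untested is meant among the compounds shown, and "the series" means these compounds.

Measured in (a functional assay on HL-60 cells (Homo sapiens) for cytotoxicity, read by MTT assay, with a stated time of 72 h; on this read-out higher numbers stand for weaker inhibition and lower numbers for stronger inhibition):
- compound 1 (`COC(=O)c1sc2c(C)cccc2c1Nc1cc(OC)c(OC)c(OC)c1`): (4270 nM)
- compound 2 (`COC(=O)c1sc2cc(OC)ccc2c1Nc1cc(OC)c(OC)c(OC)c1`): (0.4 nM)
- compound 3 (`COC(=O)c1sc2nc(C)ccc2c1Nc1cc(OC)c(OC)c(OC)c1`): (0.4 nM)

Compound 3 stands level with compound 2, the two being within the scatter of each other. Together they hold the lowest number of the three, and compound 1 lies far above them, well beyond the scatter.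

The next compound to be read is compound 4 (`COC(=O)c1sc2ncccc2c1Nc1cc(OC)c(OC)c(OC)c1`). It has hydrogen in place of methyl on an aromatic carbon, next to the ring nitrogen (hydrogen in place of methyl on an aromatic carbon).

For the measured compounds named here, no pair of measured compounds differs in one place only, so no measured step speaks directly to this change. Going by the values given here, compound 1 (4270 nM) shows only that the numbers in this small set can lie very far apart when the substitution of the shared core differs. That wide spread argues for a broad range. A moderate move toward weaker inhibition is expected, beyond the scatter but far short of the gap to compound 1. The estimated step is (a 50-fold higher number from compound 3 to compound 4 (1.70 log units; beyond the scatter)) in (this assay). Compound 4 is expected at (20 nM), with an estimated range from (0.5 nM) to (800 nM).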

Compound 4, half-maximal inhibitory concentration: 2920 nM
Compound 4: the middle estimate sits 150-fold (2.16 log units) below what was measured; measured number above the stated range.
By their numbers in this assay, from the lowest: compounds 2 and 3 (each within the scatter of the next); then compounds 4 and 1 (each within the scatter of the next).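

In this assay, for the compounds shown here, this is the only measured step that isolates one change, and it shows that the methyl on this aromatic carbon, next to the ring nitrogen, matters greatly: a 7300-fold higher number from compound 3 to compound 4 (3.86 log units; beyond the scatter). The change is small on paper: 1 heavy atom (1 carbon) leaves and a hydrogen atom enters, with 0 hydrogen-bond donors, 0 hydrogen-bond acceptors and no net charge involved, yet the number moves far beyond the scatter, so this position is highly sensitive to even a minimal edit. No measurement at hand accounts for the size of this step, and its cause remains unassigned.

Still open, as far as these compounds go, is whether the low number of compound 3 depends on methyl itself or would also hold with another group at this position, such as ethyl, methoxy, chlorine or an amine. Also open, from the compounds shown here alone, is whether hydrogen in place of methyl would give a step of similar size on a core lacking the ring nitrogen, as this single pair speaks only for the core of compound 3.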